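Chloro for Bromo on the Indole Ring

The compounds below may be only part of what the source reports. "The series", "measured", "known", "first", "only" and "open" are said of these compounds alone.

Compound 1 `COC(=O)[C@@]1(C)CCC=C2[C@@H]1CC[C@@H](C)[C@]2(C)Cc1c[nH]c2ccccc12`: 3600 nM
Compound 2 `COC(=O)[C@@]1(C)CCC=C2[C@@H]1CC[C@@H](C)[C@]2(C)Cc1c[nH]c2c(Br)cccc12`: 13000 nM

In a functional assay on HeLa cells (Homo sapiens) for inhibition, read by sulforhodamine B assay, with a stated time of 48 h (a lower number here means a stronger inhibitor of growth, a higher number a weaker inhibitor of growth), compound 2 gives the higher of the two numbers shown, the step of a 3.6-fold higher number from compound 1 to compound 2 (0.56 log units; beyond the scatter) being the only measured one. Compound 3 `COC(=O)[C@@]1(C)CCC=C2[C@@H]1CC[C@@H](C)[C@]2(C)Cc1c[nH]c2c(Cl)cccc12` differs from compound 2 by chloro in place of bromo on an aromatic carbon. Within the data shown here, no measured step bears directly on exchanging one halogen for another; only the hydrogen-to-bromo step is known, so the direction of a 1.4-fold lower number from compound 2 to compound 3 (0.16 log units; within the scatter) is uncertain and a modest move toward compound 1 is expected. For compound 3 the estimate in this assay is 9000 nM, within 4000 nM to 22000 nM.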

Compound 3, concentration for 50% growth inhibition: 14000 nM
The estimate for compound 3 lay 1.6-fold (0.19 log units) below the measured number; the range from low to high includes it.
By their numbers in this assay, from the lowest: compound 1; then compounds 2 and 3 (each within the scatter of the next).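

In this assay, the exchange of one halogen for the other on this aromatic carbon gives a 1.1-fold higher number from compound 2 to compound 3 (0.03 log units; within the scatter) and so no readable change. Chloro in place of hydrogen gives a 3.9-fold higher number from compound 1 to compound 3 (0.59 log units; beyond the scatter) and thus a rise of similar size to that seen with bromo, so the loss against compound 1 is not confined to bromo. Nothing measured here explains this result.

Going by these compounds, whether fluoro, methoxy or an amine on this carbon would also raise the number remains open. So does whether chloro on another carbon of the same ring would do so.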